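A pyridine in place of methoxyphenyl: stability outlook

The compounds below may be only part of what the source reports. "The series", "measured", "known", "first", "only" and "open" are said of these compounds alone.

Compound 1 `COc1ccc(CCOc2ccc(-c3c(C)nc(C)c([C@H](OC(C)(C)C)C(=O)O)c3N3CCC(C)(C)CC3)cc2)cc1` is measured in an ADME assay on microsomes from liver (Homo sapiens) for metabolic stability, read by LC-MS, tested at 0.5 uM (a lower number here means that the compound disappears faster, a higher number that the compound lasts longer), and gives > 2 h, which is a limit of the assay rather than a number. Compound 2 `Cc1cc(CCOc2ccc(-c3c(C)nc(C)c([C@H](OC(C)(C)C)C(=O)O)c3N3CCC(C)(C)CC3)cc2)ccc1F` gives > 2 h in this assay, likewise a limit. Compound 3 `Cc1nc(C)c([C@H](OC(C)(C)C)C(=O)O)c(N2CCC(C)(C)CC2)c1-c1ccc(OCCc2ccc(F)c(F)c2)cc1` gives > 2 h in this assay, again a limit. Thus (the limit of > 2 h in this assay, at which 3 of the 3 values shown sit), and the steps a step that the two limits leave unreadable from compound 1 to compound 2, a step that the two limits leave unreadable from compound 1 to compound 3 and a step that the two limits leave unreadable from compound 2 to compound 3 cannot be sized. The unmeasured compound 4 `Cc1nc(C)c([C@H](OC(C)(C)C)C(=O)O)c(N2CCC(C)(C)CC2)c1-c1ccc(OCCc2ccccn2)cc1` differs from compound 1 by pyridin-2-yl in place of 4-methoxyphenyl on a saturated chain carbon, two bonds along the chain from an oxygen on an aromatic ring. For the measured compounds named here, none of the measured steps bears on this change in a readable way, so no step beyond the scatter can be claimed in this assay in either direction; the most that can be expected is that compound 4 also reaches the limit. Compound 4 is therefore estimated at 3 h in this assay, between 1.2 h and 8 h, an expected step that the limit leaves unreadable from compound 1 to compound 4.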

Compound 4, half-life: 0.5 h
Compound 4: middle estimate off by 6.0-fold (0.78 log units), on the high side; measured number outside the range, below it.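

In this assay, the group on the saturated chain carbon, two bonds along the chain from an oxygen on an aromatic ring, now proves able to shift the half-life: pyridin-2-yl gives an at least 4.0-fold lower number from compound 1 to compound 4 (0.60 log units; beyond the scatter) in place of 4-methoxyphenyl, an at least 4.0-fold lower number from compound 3 to compound 4 (0.60 log units; beyond the scatter) in place of 3,4-difluorophenyl and an at least 4.0-fold lower number from compound 2 to compound 4 (0.60 log units; beyond the scatter) in place of 4-fluoro-3-methylphenyl. The starting values of all three steps are limits, so their full size stays unread, and the steps among compound 1, compound 2 and compound 3 cannot be read either: the limit of > 2 h in this assay, at which 3 of the 4 values shown sit.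

Going by these compounds, whether the drop belongs to the ring nitrogen as such stays open, as does how pyridin-3-yl, pyridin-4-yl or an unsubstituted phenyl would behave at this place.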